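This account rests on a few compounds, and the source may have more. Where it says the series, first, only, none or still open, it means among the compounds named here.

Compound 2 `CCc1cc(-c2noc(-c3cc(C)cc(CN(C)C)c3)n2)cc(C)c1OC[C@@H](O)CNC(=O)CO` gives 2.8 in a physicochemical assay for lipophilicity, in phosphate buffer, at pH 7 (a higher number here means a more lipophilic compound, a lower number a more polar compound), the lowest of the two numbers measured here. Compound 1 `CCc1cc(-c2noc(-c3cc(C)nc(CN(C)CC(C)C)c3)n2)cc(C)c1OC[C@@H](O)CNC(=O)CO` gives 3.8 in this assay, a gap beyond the scatter. Compound 3 `CCc1cc(-c2noc(-c3ccc(CN(C)CC(C)C)c(C)c3)n2)cc(C)c1OC[C@@H](O)CNC(=O)CO` sits at a limit of this assay rather than a number, at > 4.1. Compound 4 `CCc1cc(-c2noc(-c3cc(C)c(CN(C)C)s3)n2)cc(C)c1OC[C@@H](O)CNC(=O)CO` is not yet measured; it differs from compound 2 by one change, (5-((dimethylamino)methyl)-4-methylthiophen-2-yl in place of 3-((dimethylamino)methyl)-5-methylphenyl on an aromatic carbon), that is, 5-((dimethylamino)methyl)-4-methylthiophen-2-yl in place of 3-((dimethylamino)methyl)-5-methylphenyl on an aromatic carbon. Going by the values given here, no measured pair shows this kind of exchange, so the step from compound 2 to compound 4 is expected to be small, a number 0.10 log units lower from compound 2 to compound 4 (within the scatter), most likely within the scatter or slightly downward. Compound 4 is therefore estimated at 2.7, between 2.2 and 3.2.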

Compound 4, distribution coefficient: 3.2
Compound 4: middle estimate off by 0.50 log units, on the low side; measured number inside the range.
By their numbers in this assay, from the lowest: compound 2; then compound 4; then compound 1. At a limit, above all of these: compound 3.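

In this assay, 5-((dimethylamino)methyl)-4-methylthiophen-2-yl in place of 3-((dimethylamino)methyl)-5-methylphenyl gives a number 0.40 log units higher from compound 2 to compound 4 (beyond the scatter). Going by these compounds alone, this is the first measured step at this position, and it shows that exchanging the aromatic ring while keeping the dimethylaminomethyl group moves the number upward. Nothing shown here accounts for this step.

As far as these compounds go, the exchange is seen only once, so whether it carries over to the methyl(isobutyl)amino group of compound 1 stays open. From the compounds shown here alone, how a morpholine in place of the dimethylamino group on the thiophene would read also remains open.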